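The compounds below may be only part of what the source reports. "The series", "measured", "known", "first", "only" and "open" are said of these compounds alone.

This piece follows the step from compound 3, `COc1ccc(N/N=C2\CCC(C)n3c2ncc(C(=O)O)c3=O)cc1`, to compound 4, `CCOc1ccc(N/N=C2\CCC(C)n3c2ncc(C(=O)O)c3=O)cc1`. Two related compounds were also measured: compound 1, `CC1CC/C(=N\Nc2ccc(F)cc2)c2ncc(C(=O)O)c(=O)n21`, and compound 2, `CC1CC/C(=N\Nc2ccc(Br)cc2)c2ncc(C(=O)O)c(=O)n21`. In a functional assay on the whole organism for inhibition, with Rattus norvegicus as the target (a higher number here means that more compound is needed for the effect, a lower number that less compound is needed), compound 1 gives > 1000 umol/kg, which is a limit of the assay and not a number. Compound 2 gives > 1000 umol/kg in this assay, again a limit. Going by the values given here, compound 3 gives 7.6 umol/kg in this assay, the only actual number among the three, so compound 3 stands alone as the measured reference point. The measured steps are an at least 130-fold lower number from compound 1 to compound 3 (2.11 log units; beyond the scatter) and an at least 130-fold lower number from compound 2 to compound 3 (2.11 log units; beyond the scatter), both large. The step that the two limits leave unreadable from compound 1 to compound 2 cannot be read because of the limit of > 1000 umol/kg in this assay, at which 2 of the 3 values shown sit. The change to compound 4 is methyl in place of hydrogen on a saturated chain carbon bound to an oxygen on an aromatic ring. Among the compounds with values here, no measured step lengthens the methoxy group, so the known steps only show that the methoxy compound is the one with a number. A step within the usual scatter is therefore expected, in either direction. The expected step in this assay is a 1.3-fold higher number from compound 3 to compound 4 (0.12 log units; within the scatter). Compound 4 is estimated at 10 umol/kg, between 3 umol/kg and 40 umol/kg.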

Compound 4, dose for 50% inhibition: > 100 umol/kg
Compound 4 gave a limit, no number; the forecaster's own chance of this, stated with the estimate: 15%; middle value at least 10-fold (1.00 log units) from the limit.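

In this assay, replacing a hydrogen with a methyl on the saturated chain carbon bound to an oxygen on an aromatic ring turns methoxy into ethoxy and gives an at least 13-fold higher number from compound 3 to compound 4 (1.11 log units; beyond the scatter). The earlier compounds shown here compared methoxy only with fluoro and bromo, whereas this step shows that even one added methyl on the methoxy group itself costs a large part of the effect. Going by these compounds alone, compound 4 gives a limit and not a number, and the steps to it from compound 1 and from compound 2 cannot be read, so compound 3 remains the only compound with an actual number.

Going by these compounds, how much effect compound 4 really loses stays open. So does whether a hydroxy group, an amine or a longer chain such as propoxy, in place of methoxy, would keep a number close to that of compound 3.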